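The source may report more compounds than this note shows. Statements on the series, on what has been measured and on what is new or still open speak of the compounds shown alone.

In an assay for inhibition of alpha-N-acetylgalactosaminidase (Gallus gallus), tested at 1000 uM (a higher number here means more inhibition at the concentration tested (going by the name of the read-out), a lower number less inhibition), compound 1 `O=C(O)[C@@H]1NCC=C[C@@H]1O` gives 1.3%. In this assay compound 2 `O=C(O)[C@H]1NC[C@H](O)[C@@H](O)[C@@H]1O` gives 0.2%, the lower of the two numbers, though its gap to compound 1 lies within the scatter. Compound 3 `O=C(O)[C@@H]1NC[C@@H](O)[C@@H](O)[C@@H]1O` keeps every atom and bond of compound 2 and differs only in configuration: the two compounds have the same atoms and bonds and differ only in configuration as drawn: 2 of 4 stereo elements differ; a stereocentre at a saturated ring carbon is drawn S in compound 2 and R in compound 3; a stereocentre at a saturated ring carbon is drawn S in compound 2 and R in compound 3. Among the measured compounds shown here, no step between measured compounds is available to gauge such a change; with both measured numbers near the floor of the read-out, the expected step in this assay is none beyond the scatter, a number 0.8 percentage points higher from compound 2 to compound 3 (within the scatter). Compound 3 is estimated at 1%, between 0% and 8%.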

Compound 3, a percentage reported as inhibition, at one concentration (the size of the read-out at that concentration, not a potency): 7.2%
Compound 3: the middle estimate sits 6.2 percentage points below what was measured, within the range that was stated.
By their numbers in this assay, from the lowest: compounds 2, 1 and 3 (each within the scatter of the next).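

Among the compounds shown here, the pair gives the first reading of a purely configurational change in this assay, with two saturated ring carbons drawn the other way: a number 7 percentage points higher from compound 2 to compound 3 (within the scatter). For the compounds shown here, at these two stereocentres, the change therefore gives no step that can be told from the scatter. The only structural point to set against this step is: the fact that compounds 2 and 3 differ only in the configuration as drawn

The compounds shown leave open whether either stereocentre alone would move the read-out, since both change together. They also leave open how a hydroxymethyl group in place of the carboxylic acid on the shared core would read.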